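From compound 2 to compound 4: side-chain exchange

A few compounds are considered here, and "the series" means these few. Any claim that something is new, unique, unknown or untested is made for them only; others in the source may bear on it.

For the measured compounds named here, in an ADME assay (liver, Mus musculus) for metabolic stability, read by LC-MS, using microsomes, tested at 1 uM (a lower number here means that the compound disappears faster, a higher number that the compound lasts longer), compound 2 `CC(C)/C(=N/c1ccnc2cc(Cl)ccc12)NCCCCN1CCCCC1` gives 0.517 h as the only actual number so far. Compound 1 `C/C(=N/c1ccnc2cc(Cl)ccc12)NCCCCN1CCCCC1` gives > 1 h as a limit of the assay. Compound 3 `C/C(=N/c1ccnc2cc(Cl)ccc12)NC1CCN(C)CC1` gives > 1 h as a limit too. The change to compound 4 `CCN(CC)CCN/C(=N\c1ccnc2cc(Cl)ccc12)C(C)C` is diethylamino in place of 2-(piperidin-1-yl)ethyl on a saturated chain carbon, two bonds along the chain from an amine nitrogen with diethylamino in place of 2-(piperidin-1-yl)ethyl on a saturated chain carbon, two bonds along the chain from an amine nitrogen. Going by the values given here, the only measured step is an at least 1.9-fold lower number from compound 1 to compound 2 (0.28 log units; that floor lies within the scatter) and it concerns isopropyl in place of methyl, not this side chain. No shift beyond the scatter is therefore expected, and the estimated step is a 1.2-fold higher number from compound 2 to compound 4 (0.06 log units; within the scatter) in this assay with no firm direction. For compound 4 the estimated half-life is 0.6 h with 0.3 h to 1.1 h as the expected range.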

Compound 4, half-life: 0.2 h
For compound 4 the middle estimate is 3.0-fold (0.48 log units) above the measured one; measured number outside the range, below it.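

In this assay, with isopropyl held fixed, the side chain matters: diethylamino in place of 2-(piperidin-1-yl)ethyl gives a 2.6-fold lower number from compound 2 to compound 4 (0.41 log units; beyond the scatter). For the compounds shown here, this is the first step that lies beyond the scatter and the first between two actual numbers. The remaining values add no further number for comparison: the limit of > 1 h in this assay, at which 2 of the 4 values shown sit.

From the compounds shown here alone, whether the same exchange lowers the number with methyl in place of isopropyl stays open. So does the outcome with a morpholine in place of diethylamino.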